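Hydroxyphenyl in Place of Chlorophenyl on a Shared Core

The compounds below may be only part of what the source reports. "The series", "measured", "known", "first", "only" and "open" are said of these compounds alone.

Of the compounds shown here, three built on one shared core have been measured in a functional assay on SW-620 cells (Homo sapiens) for cytotoxicity, read by MTT assay, with a stated time of 72 h; a lower number here means a stronger inhibitor, a higher number a weaker inhibitor. Compound 1 `COc1cccc(/C=C2\CCC/C(=C\c3cccc(Br)c3)C2=O)c1OC` gives 8800 nM. Compound 2 `COc1ccc(/C=C2\CCC/C(=C\c3cccc(OC)c3OC)C2=O)cc1OC` gives 6400 nM. Compound 3 `COc1ccc(/C=C2\CCC/C(=C\c3cccc(Cl)c3)C2=O)cc1OC` gives 5100 nM, the lowest of the three numbers, yet its gap to compound 2 and its gap to compound 1 both lie within the scatter, so the three stand together and none of them can be called the strongest.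

Compound 4 `COc1ccc(/C=C2\CCC/C(=C\c3ccc(O)cc3)C2=O)cc1OC` has not yet been measured. It differs from compound 3 in one place: 4-hydroxyphenyl in place of 3-chlorophenyl on a double-bonded chain carbon bound to a double-bonded ring carbon. Among the compounds with values here, no step between two measured compounds matches this change, and the measured compounds carry methoxy or halogen groups on their phenyl rings only, so nothing among them shows what a hydroxyphenyl does on this core. On the numbers available, compound 4 is expected to land near compound 3. The step of a 1.2-fold higher number from compound 3 to compound 4 (0.07 log units; within the scatter) is expected to fall within the scatter rather than beyond it, in either direction. The estimate for compound 4 in this assay is 6000 nM, expected to lie between 2500 nM and 15000 nM.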

Compound 4, half-maximal inhibitory concentration: 7700 nM
Beside the measured number, compound 4's estimate is 1.3-fold (0.11 log units) below it, within the range that was stated.
By their numbers in this assay, from the lowest: compounds 3, 2, 4 and 1 (each within the scatter of the next).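

In this assay the exchange of 3-chlorophenyl for 4-hydroxyphenyl on a double-bonded chain carbon bound to a double-bonded ring carbon can now be read as a single step, and that step (a 1.5-fold higher number from compound 3 to compound 4 (0.18 log units; within the scatter)) stays inside the scatter. The earlier compounds shown here offered no such reading, and this one shows that the number does not separate from that of compound 3 even though the entering group counts 1 hydrogen-bond donor and 1 hydrogen-bond acceptor where the leaving group counts 0 of each. Nothing at hand offers a measured reason for this result.

The step changes the group and its printed position together, and the compounds shown hold no pair that tells those two changes apart, so it stays open which of them, if either, matters at this place. Also open, on these data alone, is whether an amine or a carboxylic acid on this phenyl ring, in place of the hydroxyl of compound 4, would likewise stay within the scatter of compound 3 or would move the number beyond it.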